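The source may report more compounds than this note shows. Statements on the series, on what has been measured and on what is new or still open speak of the compounds shown alone.

Working notes on the series. Compound 1 `O=Cc1ccc(-c2cn3ccnc3c(-c3ccc4ncn(C5CCCCC5)c4c3)n2)cc1` carries a formyl group on the phenyl ring attached to the shared core. Among the compounds with values here, in a functional assay on Hs-578T cells (Homo sapiens) for inhibition, read by sulforhodamine B assay, with a stated time of 48 h, tested at 10 uM (on this read-out higher numbers stand for more inhibition at the one concentration tested (going by the name of the read-out) and lower numbers for less inhibition), compound 1 gives 45.5%, the highest of the two numbers measured so far. Within the data shown here, its nearest neighbour is compound 2 `CC(=O)c1ccc(-c2cn3ccnc3c(-c3ccc4ncn(C5CCCCC5)c4c3)n2)cc1`, which in this assay gives 6.34%; the step of a number 39.2 percentage points lower from compound 1 to compound 2 (beyond the scatter) is the only measured step in the set, and it already shows that a small change at the carbonyl of compound 1 costs a large share of the inhibition.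

Compound 3 `Clc1ccc(-c2cn3ccnc3c(-c3ccc4ncn(C5CCCCC5)c4c3)n2)cc1` is not yet measured. It differs from compound 1 as follows: chloro in place of formyl on an aromatic carbon. Among the measured compounds shown here, no measured step removes the carbonyl altogether, so the only step that bears on the change is the one from compound 1 to compound 2, which is large and downward. On that basis a step downward beyond the scatter is expected in this assay, a number 23.5 percentage points lower from compound 1 to compound 3 (beyond the scatter), though with wide uncertainty because a number 39.2 percentage points lower from compound 1 to compound 2 (beyond the scatter) concerns a different substituent. For compound 3 the expected value in this assay is 22%, with a range from 0% to 55%.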

Compound 3, a percentage reported as inhibition, at one concentration (the size of the read-out at that concentration, not a potency): 6.35%
Compound 3: the middle estimate sits 15.7 percentage points above what was measured, within the range that was stated.
By their numbers in this assay, from the lowest: compounds 2 and 3 (each within the scatter of the next); then compound 1.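

In this assay, chloro in place of formyl on the aromatic carbon para to a large group gives a number 39.2 percentage points lower from compound 1 to compound 3 (beyond the scatter), so the loss at this position is not confined to the acetyl change, which gave a number 39.2 percentage points lower from compound 1 to compound 2 (beyond the scatter) and keeps a carbonyl, whereas chloro does not. Acetyl and chloro cannot be told apart here, with a number 0 percentage points higher from compound 2 to compound 3 (within the scatter), so among these three compounds only the 4-formylphenyl group of compound 1 stands apart, and having a carbonyl at this position is not enough to keep the inhibition. No measured information on these compounds bears on why formyl stands apart from the other two groups.

The compounds shown leave open whether the higher number belongs to formyl alone or would also appear with another group at this position, such as a carboxylic acid, a hydroxymethyl group, a nitrile or a primary amine. They also leave open how the three compounds would compare at other concentrations, since each number is the size of the read-out at a single concentration and not a potency.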